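Sulfonyl aryl swap: naphthalen-1-yl to naphthalen-2-yl

The source may hold more compounds than are shown below. What is called first, only, known or untested is meant among the compounds shown, and "the series" means these compounds.

Going by the values given here, in a functional assay on HEK293 cells for inhibition of 5-hydroxytryptamine receptor 6 (Homo sapiens), read by calcium flux and cAMP accumulation, with a stated time of 10 min (on this read-out lower numbers stand for stronger inhibition and higher numbers for weaker inhibition), compound 2 `CN(C)/C=N/N=C/c1cn(S(=O)(=O)c2cccc3ccccc23)c2cccc([N+](=O)[O-])c12` gives 2960 nM, the top of the two numbers so far, with the gap to compound 1 within the scatter. Compound 1 `CN(C)/C=N/N=C/c1cn(S(=O)(=O)c2ccccc2)c2cccc([N+](=O)[O-])c12` gives 1830 nM in this assay, and a 1.6-fold higher number from compound 1 to compound 2 (0.21 log units; within the scatter). Compound 3 `CN(C)/C=N/N=C/c1cn(S(=O)(=O)c2ccc3ccccc3c2)c2cccc([N+](=O)[O-])c12` differs from compound 2 by naphthalen-2-yl in place of naphthalen-1-yl on a sulfonyl sulfur. Among the compounds with values here, no measured step compares the two naphthyl attachment points; the only measured step, phenyl to naphthalen-1-yl, stayed within the scatter. The expected step is a 1.2-fold lower number from compound 2 to compound 3 (0.07 log units; within the scatter), none beyond the scatter. Compound 3 is estimated at 2500 nM, range 900 nM to 7000 nM.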

Compound 3, half-maximal inhibitory concentration: 2530 nM
The estimate for compound 3 lay 1.0-fold (0.01 log units) below the measured number; the measured number falls inside the stated range.
By their numbers in this assay, from the lowest: compounds 1, 3 and 2 (each within the scatter of the next).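

Swapping naphthalen-1-yl for naphthalen-2-yl on a sulfonyl sulfur gives a 1.2-fold lower number from compound 2 to compound 3 (0.07 log units; within the scatter) in this assay and is the first direct comparison of the two naphthyl attachment points, which are not separated here. Against phenyl, naphthalen-2-yl gives a 1.4-fold higher number from compound 1 to compound 3 (0.14 log units; within the scatter) and so also stays level with the smaller aryl group. Nothing available accounts for this lack of separation.

Open, from the compounds shown here alone, is whether any group at this position moves the number beyond the scatter. A pyridinyl ring, or a phenyl ring bearing an amine or a carboxylic acid, would test this.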